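The source may report more compounds than this note shows. Statements on the series, on what has been measured and on what is new or still open speak of the compounds shown alone.

Measured so far in a functional assay on THP-1 cells (Homo sapiens) for inhibition, read by sulforhodamine B assay, with a stated time of 48 h; on this read-out lower numbers stand for stronger inhibition and higher numbers for weaker inhibition (both values are limits):
- compound 1 (`CCO[C@H]1C[C@@H](c2coc3ccccc3c2=O)N(c2ccccc2)O1`) gives > 60000 nM as a limit
- compound 2 (`O=c1c([C@@H]2C[C@H](c3ccccc3)ON2c2ccccc2)coc2ccccc12`) gives > 60000 nM as a limit

Going by the values given here, the series so far shows only the limit of > 60000 nM in this assay, at which 2 of the 2 values shown sit, and nothing finer, so compound 2 stands at a limit and has no number. Next comes compound 3 (`NC(=O)[C@H]1C[C@@H](c2coc3ccccc3c2=O)N(c2ccccc2)O1`), with carbamoyl in place of phenyl on a saturated ring carbon. Among the compounds with values here, the one measured step on that ring carbon is a step that the two limits leave unreadable from compound 1 to compound 2 and gives no size to carry over, so no step beyond the scatter is expected in this assay in either direction. A further report at the limit is the likeliest outcome. The expected step is a number no higher from compound 2 to compound 3 (the limit leaves the size open) on this reading. Compound 3 is estimated at 60000 nM with an expected range from 25000 nM to 100000 nM for now.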

Compound 3, half-maximal inhibitory concentration: > 60000 nM
Compound 3 was reported as a limit; the forecaster's own chance of this, stated with the estimate: 75%; the middle value lies on the limit itself.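

In this assay, going by these compounds alone, compound 3 is reported only as a limit, as are compound 1 and compound 2, so no step among the three can be read: the limit of > 60000 nM in this assay, at which 3 of the 3 values shown sit.

The compounds shown leave open how ethoxy, phenyl and carbamoyl on that saturated ring carbon rank, and which change to the shared core would give a number.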